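From methyl to thiophen-2-yl on the shared core

The source may hold more compounds than are shown below. What is called first, only, known or untested is meant among the compounds shown, and "the series" means these compounds.

Measured so far in a functional assay on HL-60 cells (Homo sapiens) for inhibition, read by CCK-8 assay, with a stated time of 48 h, tested at 20 uM; on this read-out lower numbers stand for less inhibition of growth and higher numbers for more inhibition of growth at the one concentration tested:
- compound 1 (`COc1ccc(S(=O)(=O)Oc2ccccc2/C=C(\C#N)C(=O)Nc2nnc(-c3cccs3)s2)cc1`) gives 67%
- compound 2 (`Cc1ccc(S(=O)(=O)Oc2cccc(/C=C(\C#N)C(=O)Nc3nnc(C)s3)c2)cc1`) gives 71%
- compound 3 (`COc1ccc(-c2nnc(NC(=O)/C(C#N)=C/c3cccc(OS(=O)(=O)c4ccc(C)cc4)c3)s2)cc1`) gives 73%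

Compound 2 stands within the scatter of both other compounds, so the three values do not separate. Compound 4 (`Cc1ccc(S(=O)(=O)Oc2cccc(/C=C(\C#N)C(=O)Nc3nnc(-c4cccs4)s3)c2)cc1`) arises from compound 2 through a single change (thiophen-2-yl in place of methyl on an aromatic carbon), thiophen-2-yl in place of methyl on an aromatic carbon. Going by the values given here, the one measured step at this place, with 4-methoxyphenyl in place of methyl, is a number 2 percentage points higher from compound 2 to compound 3 (within the scatter) and so gives no sign of a real shift. Compound 1 also carries thiophen-2-yl but differs elsewhere, and its value also lies within the scatter of compound 2. In this assay the expected step is a number 1 percentage points higher from compound 2 to compound 4 (within the scatter) and thus none beyond the scatter. For compound 4 the estimated value is 72% within an expected range of 62% to 82%.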

Compound 4, percent growth inhibition at one concentration: 62%
Compound 4: the middle estimate sits 10 percentage points above what was measured; the measured number falls inside the stated range.
By their numbers in this assay, from the lowest: compounds 4, 1, 2 and 3 (each within the scatter of the next, the first and the last beyond it).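

In this assay, going by these compounds alone, thiophen-2-yl in place of 4-methoxyphenyl gives a number 11 percentage points lower from compound 3 to compound 4 (beyond the scatter), the first step at this position to pass the scatter, whereas thiophen-2-yl in place of methyl gives a number 9 percentage points lower from compound 2 to compound 4 (within the scatter). The position therefore does respond to its substituent, but only the two ring-bearing groups separate, and methyl stays within the scatter of both. Nothing at hand accounts for this gap between the two rings. The compounds shown leave open whether plain phenyl would side with 4-methoxyphenyl or with thiophen-2-yl. They also leave open how an amine or a carboxylic acid at this carbon would read.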